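A Nitrobenzyl Arm in Place of the Pentyl Chain

The source may hold more compounds than are shown below. What is called first, only, known or untested is meant among the compounds shown, and "the series" means these compounds.

Measured compounds:
compound 1 `CCCCCNc1ncnc2c1ncn2[C@@H]1O[C@H](CO)[C@@H](O)[C@H]1O`: 13500 nM
compound 2 `OC[C@H]1O[C@@H](n2cnc3c(SC4CCCCC4)ncnc32)[C@H](O)[C@@H]1O`: 6310 nM
compound 3 `OC[C@H]1O[C@@H](n2cnc3c(Sc4ccccc4)ncnc32)[C@H](O)[C@@H]1O`: 91200 nM

In an assay on isolated protein for binding affinity to Equilibrative nucleoside transporter 1 (Homo sapiens) (on this read-out higher numbers stand for weaker inhibition and lower numbers for stronger inhibition), compound 1 stands second highest of the three numbers. Its neighbours are compound 2, reached by a 2.1-fold lower number from compound 1 to compound 2 (0.33 log units; beyond the scatter), and compound 3, reached by a 6.8-fold higher number from compound 1 to compound 3 (0.83 log units; beyond the scatter). Compound 4 `Cc1ccc(CNc2ncnc3c2ncn3[C@@H]2O[C@H](CO)[C@@H](O)[C@H]2O)cc1[N+](=O)[O-]` differs from compound 1 as follows: 4-methyl-3-nitrophenyl in place of butyl on a saturated chain carbon bound to a nitrogen on an aromatic ring. Within the data shown here, no measured step covers this change. Among the measured compounds shown here, the only step in which an aromatic ring enters is a 14-fold higher number from compound 2 to compound 3 (1.16 log units; beyond the scatter), but there the ring sits on a sulfur, not on a saturated chain carbon, so it guides only loosely. The step is therefore expected to be modest and uncertain in direction. Compound 4 is estimated at 3000 nM, within 300 nM to 30000 nM. That estimate is expected to mean a 4.5-fold lower number from compound 1 to compound 4 (0.65 log units; beyond the scatter).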

Compound 4, half-maximal inhibitory concentration: 1170 nM
Estimate against measurement, compound 4: 2.6-fold (0.41 log units) above; low and high end bracket the measured number.
By their numbers in this assay, from the lowest: compound 4; then compound 2; then compound 1; then compound 3.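

In this assay, 4-methyl-3-nitrophenyl in place of butyl gives a 12-fold lower number from compound 1 to compound 4 (1.06 log units; beyond the scatter), so an aromatic ring on this saturated chain carbon goes with stronger inhibition. Earlier, the only aromatic ring entered on a sulfur, and there the change went the other way, with a 14-fold higher number from compound 2 to compound 3 (1.16 log units; beyond the scatter). Nothing measured here gives a reason for the new step. The compounds shown leave open how much of the step belongs to the ring itself and how much to its methyl and nitro groups. A plain phenyl in the same place, or an amine in place of the nitro, would help divide it.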